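The source may hold more compounds than are shown below. What is called first, only, known or untested is meant among the compounds shown, and "the series" means these compounds.

Measured in a functional assay on HepG2 cells (Homo sapiens) for antiproliferative activity, read by MTT assay, with a stated time of 48 h; on this read-out lower numbers stand for stronger inhibition and higher numbers for weaker inhibition:
- compound 1 `CCn1c(C(=O)NCCCN(C)C)ccc1C(CC)(CC)c1ccc(OCCC(O)(CC)CC)c(C)c1`: 110 nM
- compound 2 `CCOC(=O)C(CC(=O)OC)NC(=O)c1ccc(C(CC)(CC)c2ccc(OCCC(O)(CC)CC)c(C)c2)n1CC`: > 50000 nM
- compound 3 `CCC(C)C(NC(=O)c1ccc(C(CC)(CC)c2ccc(OCCC(O)(CC)CC)c(C)c2)n1CC)C(=O)O`: 2620 nM

The entry for compound 2 is a limit of the assay and not a number. Of the two true numbers, the higher belongs to compound 3, and the step to it is a 24-fold higher number from compound 1 to compound 3 (1.38 log units; beyond the scatter).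

Compound 4 `CCn1c(C(=O)NC(CO)CCO)ccc1C(CC)(CC)c1ccc(OCCC(O)(CC)CC)c(C)c1` has not yet been measured. It carries 3-hydroxy-1-(hydroxymethyl)propyl in place of 1-carboxy-2-methylbutyl on an amide-type nitrogen.

Earlier changes at this same nitrogen all mattered. One was an at least 450-fold higher number from compound 1 to compound 2 (2.65 log units; beyond the scatter), and another was an at least 19-fold lower number from compound 2 to compound 3 (1.28 log units; beyond the scatter). A change here can therefore move the number a long way, so a step beyond the scatter is plausible in this assay. The new group lacks the 3-(dimethylamino)propyl of compound 1, which gave the lowest number at 110 nM, so a drop to that level seems unlikely. A modest rise is more likely, though the direction remains uncertain.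

The expected change is a 3.1-fold higher number from compound 3 to compound 4 (0.48 log units; beyond the scatter). For compound 4 the estimated value is 8000 nM, with an expected range of 1500 nM to 40000 nM.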

Compound 4, half-maximal inhibitory concentration: 24800 nM
For compound 4 the middle estimate is 3.1-fold (0.49 log units) below the measured one; low and high end bracket the measured number.
By their numbers in this assay, from the lowest: compound 1; then compound 3; then compound 4. At a limit, above all of these: compound 2.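

3-hydroxy-1-(hydroxymethyl)propyl in place of 1-carboxy-2-methylbutyl on an amide-type nitrogen, with two hydroxyl groups and no carboxylic acid, gives a 9.5-fold higher number from compound 3 to compound 4 (0.98 log units; beyond the scatter), so removing the acid does not by itself lower the number. The two hydroxyl groups also fall far short of the 3-(dimethylamino)propyl group, with a 230-fold higher number from compound 1 to compound 4 (2.35 log units; beyond the scatter), and of the three compounds with true numbers, only compound 1, which carries that amine chain, reaches the low range. Compound 2 stands at a limit of the assay and not at a number: the limit of > 50000 nM in this assay, at which 1 of the 4 values shown sits. Read against that limit, the data give an at least 2.0-fold lower number from compound 2 to compound 4 (0.30 log units; that floor lies within the scatter).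

The compounds shown leave open whether the low number of compound 1 depends on its amine nitrogen or on the shape of its unbranched chain. A plain 3-hydroxypropyl group, or a primary amine on the same chain, would help to separate these two possibilities.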